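The source may report more compounds than this note shows. Statements on the series, on what has been measured and on what is new or still open speak of the compounds shown alone.

Values so far in an ADME assay for permeability, using PAMPA, with a stated time of 4 h; on this read-out higher numbers stand for higher permeability and lower numbers for lower permeability:
- compound 1 `Cc1cc(C)cc(Oc2ccc3nc(COc4cccc(C(=O)O)c4)n(C)c3n2)c1` gives 17.4 10^-6 cm/s
- compound 2 `Cn1c(COc2cccc(C(=O)O)c2)nc2cnc(Oc3ccc4c(c3)OCC4)cc21` gives 3.6 10^-6 cm/s
- compound 3 `Cn1c(COc2cccc(C(=O)O)c2)nc2ccc(Oc3ccc(Cl)cn3)cc21` gives 16.2 10^-6 cm/s

Compound 3 stands level with compound 1 within the scatter, while compound 2 lies lower, beyond the scatter. Compound 4 `Cc1cccc(Oc2ccc3nc(COc4cccc(C(=O)O)c4)n(C)c3c2)n1` carries 6-methylpyridin-2-yl in place of 5-chloropyridin-2-yl on an oxygen on an aromatic ring. For the measured compounds named here, no measured pair isolates a single change, so support is indirect. Compound 3 at 16.2 10^-6 cm/s is the direct reference. In this assay no shift beyond the scatter is expected. The estimated change is a 1.2-fold lower number from compound 3 to compound 4 (0.06 log units; within the scatter) and is expected to stay within the scatter. Compound 4 is estimated at 14 10^-6 cm/s with an expected range of 7 10^-6 cm/s to 26 10^-6 cm/s for now.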

Compound 4, apparent permeability: 2.7 10^-6 cm/s
Compound 4: the middle estimate sits 5.2-fold (0.71 log units) above what was measured; the measured number lies below the stated range.
By their numbers in this assay, from the lowest: compounds 4 and 2 (each within the scatter of the next); then compounds 3 and 1 (each within the scatter of the next).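

In this assay, the group on an oxygen on an aromatic ring is not freely interchangeable: 6-methylpyridin-2-yl in place of 5-chloropyridin-2-yl gives a 6.0-fold lower number from compound 3 to compound 4 (0.78 log units; beyond the scatter) even though heavy-atom and hydrogen-bond counts match. For the compounds shown here, this is the only step so far that isolates one change, and it is the first direct reading at this place. Nothing at hand accounts for the size of the step. Still open, on these data alone, is whether the step follows the change of substituent or its place on the ring. The unsubstituted pyridin-2-yl, 5-methylpyridin-2-yl and 6-chloropyridin-2-yl groups would separate those two readings.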